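Thiophen-3-yl in place of furan-2-yl in compound 2

This account rests on a few compounds, and the source may have more. Where it says the series, first, only, none or still open, it means among the compounds named here.

Among the measured compounds shown here, in a functional assay on K562 cells (Homo sapiens) for inhibition, with a stated time of 72 h (on this read-out lower numbers stand for stronger inhibition and higher numbers for weaker inhibition), compound 1 (`NC1CCC(Nc2nc(NCc3ccc(-c4cccc(F)c4)nc3)c3ncn(C4CCCC4)c3n2)CC1`) gives 61 nM and compound 2 (`NC1CCC(Nc2nc(NCc3ccc(-c4ccco4)nc3)c3ncn(C4CCCC4)c3n2)CC1`) gives 67 nM, so compound 2 stands within the scatter of the only other measured value. Compound 3 (`NC1CCC(Nc2nc(NCc3ccc(-c4ccsc4)nc3)c3ncn(C4CCCC4)c3n2)CC1`) carries thiophen-3-yl in place of furan-2-yl on an aromatic carbon. For the measured compounds named here, the single measured step at this place, a 1.1-fold higher number from compound 1 to compound 2 (0.04 log units; within the scatter), stayed within the scatter. No step beyond the scatter is therefore expected in this assay, though one step is thin evidence. The expected step is a 1.1-fold lower number from compound 2 to compound 3 (0.03 log units; within the scatter). Compound 3 is estimated at 62 nM, with an expected range of 28 nM to 135 nM.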

Compound 3, half-maximal inhibitory concentration: 150 nM
Compound 3: middle estimate off by 2.4-fold (0.38 log units), on the low side; the measured number lies above the stated range.
By their numbers in this assay, from the lowest: compounds 1 and 2 (each within the scatter of the next); then compound 3.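

In this assay this aromatic carbon, next to the ring nitrogen, shows a 2.2-fold higher number from compound 2 to compound 3 (0.35 log units; beyond the scatter) and a 2.5-fold higher number from compound 1 to compound 3 (0.39 log units; beyond the scatter) as its substituent changes, so the group here can matter. Furan-2-yl and thiophen-3-yl have the same counts of heavy atoms, donors and acceptors, so those counts do not separate them. No measurement at hand accounts for this step. The compounds shown leave open whether the change of hetero atom or the change of attachment point matters, which thiophen-2-yl and furan-3-yl would separate. They also leave open how an amine or a carboxylic acid on the ring would read out here.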